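Adding 4-methoxybenzyl to the ring nitrogen: no gain expected

The compounds below may be only part of what the source reports. "The series", "measured", "known", "first", "only" and "open" are said of these compounds alone.

Measured so far:
compound 1 `COc1ccc(Cn2nc(-c3ccccc3)c3cc(C(=N)Nc4cccc(C(F)(F)F)c4)ncc32)cc1`: > 50000 nM
compound 2 `N=C(Nc1cccc(C(F)(F)F)c1)c1cc2cn[nH]c2cn1`: > 50000 nM

Both figures come from a functional assay on MDA-MB-231 cells (Homo sapiens) for cytotoxicity, read by MTT assay, with a stated time of 72 h; a higher number here means a weaker inhibitor, a lower number a stronger inhibitor. The value for compound 1 is a limit of the assay, not a number. The value for compound 2 is likewise a limit, not a number, so compound 2 stands only at the edge of what the assay reports; it cannot be ordered against compound 1, since the limit of > 50000 nM in this assay, at which 2 of the 2 values shown sit, holds both.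

Compound 3 `COc1ccc(Cn2ncc3cc(C(=N)Nc4cccc(C(F)(F)F)c4)ncc32)cc1` is not yet measured. It differs from compound 2 by 4-methoxybenzyl in place of hydrogen on an aromatic nitrogen. Among the measured compounds shown here, no measured step shows what this change does on its own. Compound 1 carries the same 4-methoxybenzyl group together with a further phenyl and still gives only a limit, so no step beyond the scatter is expected in this assay; the step from compound 2 to compound 3 is estimated at a step that the limit leaves unreadable from compound 2 to compound 3. Compound 3 is therefore expected at 70000 nM, in the range 20000 nM to 250000 nM, most likely reported again as a limit.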

Compound 3, half-maximal inhibitory concentration: 29800 nM
For compound 3 the middle estimate is 2.3-fold (0.37 log units) above the measured one; the range from low to high includes it.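

In this assay, compound 3 is the only compound shown that gives a number rather than a limit, so 4-methoxybenzyl on the aromatic nitrogen is compatible with a readable value when no phenyl sits on the aromatic carbon. The change on the nitrogen gives an at least 1.6-fold lower number from compound 2 to compound 3 (0.22 log units; that floor lies within the scatter), and removing the phenyl gives an at least 1.6-fold lower number from compound 1 to compound 3 (0.22 log units; that floor lies within the scatter). Neither step has a readable full size, and neither can be shown to exceed the scatter, because only floors are available: the limit of > 50000 nM in this assay, at which 2 of the 3 values shown sit.

Still open, from the compounds shown here alone, is whether the methoxy group contributes, or whether a plain benzyl or a short alkyl chain on the same nitrogen would also give a number in this assay. The compounds shown also leave open whether an amine on the benzyl ring would move the value.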